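Flipping One Ring Stereocentre in a Thiadiazole Series

The source may hold more compounds than are shown below. What is called first, only, known or untested is meant among the compounds shown, and "the series" means these compounds.

Measured compounds:
compound 1, `CCCCSc1nsnc1[C@H]1CN2CCC[C@H]1C2`, gives > 1 mg/kg in a functional assay on the whole organism with Mus musculus as the target; on this read-out higher numbers stand for an effect only at larger amounts of compound and lower numbers for an effect already at smaller amounts; this value is a limit of the assay, not a number
compound 2, `CCCSc1nsnc1[C@H]1CN2CCC[C@@H]1C2`, gives 2.2 mg/kg in this assay
compound 3, `CCCSc1nsnc1[C@@H]1CN2CCC[C@H]1C2`, gives 1.3 mg/kg in this assay

Compound 3 holds the lowest of the two numbers shown, with compound 2 nearest to it; the step of a 1.7-fold lower number from compound 2 to compound 3 (0.23 log units; within the scatter) does not rise above the scatter, and in that step both ring stereocentres change at once. Compound 1 is drawn with the same ring configuration as compound 4 but carries a butylthio chain, and its result is only a limit, (the limit of > 1 mg/kg in this assay, at which 1 of the 3 values shown sits), so it gives no number to lean on.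

Compound 4, `CCCSc1nsnc1[C@H]1CN2CCC[C@H]1C2`, is not yet measured. Compared with compound 3 the change is the two compounds have the same atoms and bonds; at least one stereo element is drawn with a configuration in one of them and without one in the other: 1 of 3 stereo elements differ; a stereocentre at a saturated ring carbon is drawn S in compound 3 and R in compound 4: nothing leaves and nothing enters; one stereocentre at a saturated ring carbon is drawn S in compound 3 and R in compound 4. Going by the values given here, the only measured step bearing on a stereochemical change is the one from compound 2 to compound 3, and it stayed within the scatter. The expectation for compound 4 is therefore a step of a 1.3-fold higher number from compound 3 to compound 4 (0.12 log units; within the scatter), close to no change, with the estimate 1.7 mg/kg and a range from 0.6 mg/kg to 5 mg/kg.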

Compound 4, dose for half-maximal effect: > 30 mg/kg
Compound 4 was reported as a limit; the forecaster's own chance of this, stated with the estimate: 30%; at least 17-fold (1.24 log units) between middle value and limit.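

In this assay compound 4 gives > 30 mg/kg, which is a limit of the assay and not a number. Inverting one stereocentre at a saturated ring carbon, with nothing leaving and nothing entering, now gives an at least 23-fold higher number from compound 3 to compound 4 (1.36 log units; beyond the scatter), and inverting the other gives an at least 13-fold higher number from compound 2 to compound 4 (1.13 log units; beyond the scatter). Compounds 2 and 3, whose two ring stereocentres are both drawn opposite to each other, stayed within the scatter, so the earlier data made configuration look unimportant, whereas compound 4 shows that in this series the way the two stereocentres are paired decides whether an effect appears at small doses, not either centre taken alone.

From the compounds shown here alone, the step from compound 1 to compound 4 cannot be read, as both values are limits, so the effect of the butylthio chain in this ring configuration stays unknown. Also open, going by these compounds, is whether the gap between these configurations survives when the propylthio chain gives way to a longer chain such as hexylthio or to an amine.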